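Removing a ring methyl: metabolic stability of a matched pair

The compounds below may be only part of what the source reports. "The series", "measured", "known", "first", "only" and "open" are said of these compounds alone.

Measured compounds:
- compound 1, `C[C@]1(O)C[C@](c2cccc(OC(F)(F)F)c2)([C@H](O)c2ccccn2)C1`: 117 mL/min/kg
- compound 2, `O[C@H](c1ccccn1)[C@]1(c2cccc(OC(F)(F)F)c2)C[C@H](O)C1`: 150 mL/min/kg
- compound 3, `C[C@]1(O)C[C@](c2ccnc(C(F)(F)F)c2)([C@H](O)c2ccccn2)C1`: 66.7 mL/min/kg

In an ADME assay on liver for metabolic stability, with Liver microsome (Homo sapiens) as the target, read by LC-MS, using microsomes, with a stated time of 5 h (a lower number here means slower removal, a higher number faster removal of the compound), compound 1 gives 117 mL/min/kg, while compound 2 gives 150 mL/min/kg. The two differ by hydrogen in place of methyl on a saturated ring carbon, and the step is a 1.3-fold higher number from compound 1 to compound 2 (0.11 log units; within the scatter). Compound 3 gives 66.7 mL/min/kg in this assay; its value stands closest to that of compound 1 and furthest from that of compound 2, and how its core differs from the core of compound 1 is not broken down here.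

Compound 4, `O[C@H](c1ccccn1)[C@]1(c2ccnc(C(F)(F)F)c2)C[C@H](O)C1`, has not yet been measured. It differs from compound 3 by hydrogen in place of methyl on a saturated ring carbon, the same change as that from compound 1 to compound 2. Because the earlier step was a 1.3-fold higher number from compound 1 to compound 2 (0.11 log units; within the scatter), a comparable step, a 1.3-fold higher number from compound 3 to compound 4 (0.11 log units; within the scatter), is expected here, resting only on that single matched pair. Compound 4 is therefore expected to give about 85 mL/min/kg in this assay, within a range from 50 mL/min/kg to 145 mL/min/kg.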

Compound 4, clearance: 33.3 mL/min/kg
For compound 4 the middle estimate is 2.6-fold (0.41 log units) above the measured one, outside the stated range (below it).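

In this assay, the new matched pair, with hydrogen in place of methyl on a saturated ring carbon, shows a 2.0-fold lower number from compound 3 to compound 4 (0.30 log units; within the scatter). Set beside the earlier step, the result does not separate the two cores: the same change on two cores in this assay, a 1.3-fold higher number (0.11 log units; within the scatter) from compound 1 to compound 2 and a 2.0-fold lower number (0.30 log units; within the scatter) from compound 3 to compound 4, 2.6-fold (0.41 log units) apart, within the scatter of two such steps. Among the compounds shown here, this gives no sign that the change behaves differently from one core to the other, but it does not establish a shared effect either, as each step and the gap between them lie within the scatter and only two matched pairs bear on the question.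

The compounds shown carry only methyl or hydrogen at this ring carbon, so the outcome with an ethyl group, a fluorine atom or an amine there remains open. Also open, as far as these compounds go, is whether the same change would give a comparable step on a core carrying a nitrile or a carboxylic acid instead of the trifluoromethyl or trifluoromethoxy group.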